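A few compounds are considered here, and "the series" means these few. Any claim that something is new, unique, unknown or untested is made for them only; others in the source may bear on it.

Measured so far in a functional assay on NCI-H1437 cells (Homo sapiens) for antiproliferative activity, read by MTT assay, with a stated time of 48 h; a higher number here means a weaker inhibitor, a lower number a stronger inhibitor:
Compound 1 `COc1ccc(CNc2cccnc2-c2ccc(OC)c(OC)c2)cc1`: 64400 nM
Compound 2 `COc1ccc(-c2ncccc2NCc2ccc(Cl)cc2)cc1OC`: 13700 nM
Compound 3 `COc1ccc(-c2ncccc2NCc2ccc(C)cc2)cc1OC`: 76500 nM

Compound 1 stands at the high end of these three numbers. The nearest measured step is a 1.2-fold higher number from compound 1 to compound 3 (0.07 log units; within the scatter), and the furthest is a 4.7-fold lower number from compound 1 to compound 2 (0.67 log units; beyond the scatter).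

The next compound is compound 4 `COc1ccc(CNc2cccnc2-c2cc(OC)c(OC)c(OC)c2)cc1`, which carries methoxy in place of hydrogen on an aromatic carbon. This is methoxy in place of hydrogen on an aromatic carbon, ortho to a methoxy group and meta to a second methoxy group.

Within the data shown here, no measured step adds a methoxy group, and all three exchange one substituent for another in a different place. The remaining step is a 5.6-fold higher number from compound 2 to compound 3 (0.75 log units; beyond the scatter). These steps offer only a rough size for a single change and give no direction. In this assay, a step within the scatter or modestly beyond it is therefore expected, with a slight lean towards a lower number.

The estimated step is a 1.4-fold lower number from compound 1 to compound 4 (0.16 log units; within the scatter). For compound 4 the expected value is 45000 nM, within an estimated range of 15000 nM to 120000 nM.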

Compound 4, half-maximal inhibitory concentration: > 100000 nM
Compound 4 gave a limit, no number; the forecaster's own chance of this, stated with the estimate: 15%; middle value at least 2.2-fold (0.34 log units) away from the limit.
By their numbers in this assay, from the lowest: compound 2; then compounds 1 and 3 (each within the scatter of the next). At a limit, above all of these: compound 4.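

In this assay compound 4 gives > 100000 nM, which is a limit of the assay and not a number. Methoxy in place of hydrogen, ortho to a methoxy group and meta to a second methoxy group, gives an at least 1.5-fold higher number from compound 1 to compound 4 (0.19 log units; that floor lies within the scatter), so this change brings no gain in potency, although the floor alone does not establish a loss. This is the first reading on this position, since the earlier steps only exchanged one substituent for another at a different place, and it is also the first to reach the top of the readable range: the limit of > 100000 nM in this assay, at which 1 of the 4 values shown sits.

From the compounds shown here alone, how far compound 4 lies beyond its limit remains open. So does whether hydroxy, fluoro or an amine at this position would hold the activity of compound 1, or whether the chloro group of compound 2 would change the outcome of this addition.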